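Turning one double bond in compound 2

The compounds below may be only part of what the source reports. "The series", "measured", "known", "first", "only" and "open" are said of these compounds alone.

In a functional assay on K562 cells (Homo sapiens) for cytotoxicity, read by sulforhodamine B assay, with a stated time of 48 h (a lower number here means a stronger inhibitor, a higher number a weaker inhibitor), compound 2 `CCN(CC)CCCn1c(=O)/c(=C/c2ccccc2O)s/c1=C1\C(=O)Nc2ccc(C)cc21` reads 14800 nM and is the weakest of the three measured. Among the compounds with values here, compound 1 `CCN(CC)CCCn1c(=O)/c(=C/c2cc(OC)c(OC)c(OC)c2)s/c1=C1/C(=O)Nc2ccc(C)cc21` reads 4170 nM and compound 3 `CCN(CC)CCCn1c(=O)/c(=C/c2cc(OC)c(OC)c(OC)c2)s/c1=C1\C(=O)Nc2ccc(C)cc21` reads 4170 nM with 3,4,5-trimethoxyphenyl in place of 2-hydroxyphenyl, a swap that gives a 3.5-fold lower number from compound 2 to compound 3 (0.55 log units; beyond the scatter) as the only substituent step. For compound 4 `CCN(CC)CCCn1c(=O)/c(=C/c2ccccc2O)s/c1=C1/C(=O)Nc2ccc(C)cc21` the change is the two compounds have the same atoms and bonds and differ only in configuration as drawn: 1 of 2 stereo elements differ; a double bond is drawn Z in compound 2 and E in compound 4 with no other edit. Within the data shown here, the one measured precedent, resting on the fact that compounds 1 and 3 differ only in the configuration as drawn as its sole difference, is no change at the digits printed from compound 1 to compound 3 (within the scatter) and it carries 3,4,5-trimethoxyphenyl, not 2-hydroxyphenyl. No step beyond the scatter is therefore expected in either direction, and no change at the digits printed from compound 2 to compound 4 (within the scatter) is the expected step in this assay for this change. Compound 4 is estimated at 14800 nM with an expected range from 7000 nM to 30000 nM overall.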

Compound 4, half-maximal inhibitory concentration: 14800 nM
Compound 4: the middle estimate sits on the measured number at the digits printed; low and high end bracket the measured number.
By their numbers in this assay, from the lowest: compounds 1 and 3 (each within the scatter of the next); then compounds 2 and 4 (each within the scatter of the next).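

In this assay, the drawn configuration of the double bond is now silent on a second aryl group, 2-hydroxyphenyl as well as 3,4,5-trimethoxyphenyl, with no change at the digits printed from compound 2 to compound 4 (within the scatter). The aryl swap also reads the same with this double bond drawn E, with a 3.5-fold higher number from compound 1 to compound 4 (0.55 log units; beyond the scatter), so the substituent step does not depend on the drawing: the same change on two cores in this assay, a 3.5-fold lower number (0.55 log units; beyond the scatter) from compound 2 to compound 3 and a 3.5-fold lower number (0.55 log units; beyond the scatter) from compound 4 to compound 1, 1.0-fold (0.00 log units) apart, within the scatter of two such steps

Going by these compounds, whether configuration stays silent with an amine or a carboxylic acid in place of these aryl groups remains open. Also open is which of the three methoxy groups, if any single one, accounts for the substituent step.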